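A Fluorine on the Benzyl Ring of a Modulator

This account rests on a few compounds, and the source may have more. Where it says the series, first, only, none or still open, it means among the compounds named here.

Three compounds share one core: a piperidine bearing an amide on one side and a sulfonyl group on the other. Compound 1 `CCN(Cc1ccccc1)C(=O)C1CCN(S(=O)(=O)c2c[nH]cn2)CC1` carries a small nitrogen-containing ring on the sulfonyl sulfur, and in a functional assay on CHO cells for positive allosteric modulation of muscarinic acetylcholine receptor M5 (Homo sapiens), read by calcium flux (a lower number here means a smaller maximal response, a higher number a larger maximal response), compound 1 has "not determined" (no result reported). Compound 2 `CCN(Cc1ccccc1)C(=O)C1CCN(S(=O)(=O)c2ccc(C)s2)CC1` gives 64% in this assay, and compound 3 `CCN(Cc1ccccc1)C(=O)C1CCN(S(=O)(=O)c2ccc3cn[nH]c3c2)CC1` gives 86%. Among the measured compounds shown here, the only measured step, a number 22 percentage points higher from compound 2 to compound 3 (beyond the scatter), concerns the group on the sulfonyl sulfur. Among the two numbers known, compound 3 stands highest; only compound 2 comes near, and that gap lies beyond the scatter.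

Compound 4 `CCN(Cc1ccccc1F)C(=O)C1CCN(S(=O)(=O)c2ccc3cn[nH]c3c2)CC1` keeps the sulfonyl side of compound 3 unchanged and alters the other end instead: fluoro in place of hydrogen on an aromatic carbon. For the measured compounds named here, no measured step touches this benzyl ring, so the change from phenyl to 2-fluorophenyl has no direct precedent here, and the one known step, on the opposite side of the molecule, says nothing about it. A single fluorine entering, with no ring and no donor or acceptor, is a small change, so the response of compound 4 is expected to stay close to that of compound 3, with the estimated step of a number 4 percentage points lower from compound 3 to compound 4 (within the scatter) lying within the scatter. For compound 4 the expected value in this assay is 82%, within a range from 65% to 100%.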

Compound 4, largest response reached (reported as percent of maximum), in percent of the reference or control that the assay uses: 84%
Beside the measured number, compound 4's estimate is 2 percentage points below it; measured number inside the range.
By their numbers in this assay, from the lowest: compound 2; then compounds 4 and 3 (each within the scatter of the next).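

In this assay, among the compounds shown here, fluoro in place of hydrogen on an aromatic carbon gives a number 2 percentage points lower from compound 3 to compound 4 (within the scatter), and this is the first measured step at the benzyl end of the molecule. For the compounds shown here, it shows that this end can take a fluorine on a carbon ortho to a large group, turning benzyl into 2-fluorobenzyl, with no response that can be told apart from that of compound 3, whereas the one earlier step, on the sulfonyl side, went beyond the scatter. Nothing measured here offers an explanation for this result.

On these data alone, one small atom at one place on this ring says little about the ring as a whole, so it remains open how the response would behave with a larger or quite different group there, such as a chlorine atom, a methoxy group or an amine, or with the same fluorine elsewhere on the ring. Also open is the ethyl group on the amide nitrogen, which stays the same in every compound shown, so a longer chain or a carboxylic acid at its end has no number to go on.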